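Pentyl to propyl: a step from a limit

The source may hold more compounds than are shown below. What is called first, only, known or untested is meant among the compounds shown, and "the series" means these compounds.

In an ADME assay on CCRF-HSB-2 cells (Homo sapiens) for cytotoxicity, with a stated time of 7 days (a lower number here means that less compound is tolerated, a higher number that more compound is tolerated), compound 1 `CCCCCCCCSc1nc(N)nc2c1ncn2/C=C1/CC1(CO)CO` gives 60000 nM as a measured value. Compound 2 `CCCCCOc1nc(N)nc2c1ncn2/C=C1/CC1(CO)CO` gives > 20000 nM as a limit of the assay and not a number. Compound 3 `CCCOc1nc(N)nc2c1ncn2/C=C1/CC1(CO)CO` differs from compound 2 by hydrogen in place of ethyl on a saturated chain carbon, three bonds along the chain from an oxygen on an aromatic ring in a change that reads pentyl to propyl. Among the measured compounds shown here, the one measured step is a step that the limit leaves unreadable from compound 1 to compound 2 and offers no size to carry over. With no readable step to draw on, no change beyond the scatter is expected and no direction is favoured. The expected step is a step that the limit leaves unreadable from compound 2 to compound 3 in size. For compound 3 the estimate is 35000 nM with an expected range from 12000 nM to 100000 nM as the half-maximal cytotoxic concentration.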

Compound 3, half-maximal cytotoxic concentration: > 20000 nM
Compound 3 gave a limit, no number; the forecaster's own chance of this, stated with the estimate: 60%; the middle value is on the limit's open side.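

No new step can be read from compound 3 against compound 1 or compound 2, because compound 2 and compound 3 both end in a limit and not a number: the limit of > 20000 nM in this assay, at which 2 of the 3 values shown sit.

Left open are the actual values of compound 2 and compound 3, and whether pentyl to propyl shifts the read-out at all.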